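This account rests on a few compounds, and the source may have more. Where it says the series, first, only, none or still open, it means among the compounds named here.

Compound 2, `COc1cccc(CNCCCNc2ccnc3cc(-c4ccc(F)cc4)ccc23)c1O`, is one of two members of a shared core that have been measured so far. In an ADME assay on HepG2 cells (Homo sapiens) for cytotoxicity, read by luminescence, CellTiter-Glo and ATP content, with a stated time of 72 h (a lower number here means that less compound is needed, a higher number that more compound is needed for the effect), compound 2 gives 6840 nM, which is the highest of the two numbers recorded. Its nearest neighbour, compound 1, `COc1cccc(CNCCCNc2ccnc3cc(-c4ccccc4)ccc23)c1O`, gives in this assay a value of 3210 nM. Among the measured compounds shown here, the one measured step between them, a 2.1-fold higher number from compound 1 to compound 2 (0.33 log units; beyond the scatter), arises from a single change, fluoro in place of hydrogen on an aromatic carbon.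

Compound 3, `COc1cccc(CNCCCNc2ccnc3cc(Oc4ccc(C(C)(C)C)cc4)ccc23)c1O`, has not yet been measured. It differs from compound 2 in one place: 4-(tert-butyl)phenoxy in place of 4-fluorophenyl on an aromatic carbon. For the measured compounds named here, this exchange removes the whole 4-fluorophenyl group and puts 4-(tert-butyl)phenoxy in its place, a much bigger change than the single fluorine-for-hydrogen swap seen between compound 1 and compound 2. That one step was modest and offers no direct guide for a change of this kind, so the measured data give no firm basis for predicting either a rise or a fall in this assay. For compound 3 the estimated value in this assay is 5000 nM, with a range from 1500 nM to 16000 nM. The step this estimate implies is expected to be a 1.4-fold lower number from compound 2 to compound 3 (0.14 log units; within the scatter).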

Compound 3, half-maximal effective concentration: 1500 nM
The estimate for compound 3 lay 3.3-fold (0.52 log units) above the measured number; measured number inside the range.
By their numbers in this assay, from the lowest: compound 3; then compound 1; then compound 2.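

In this assay, putting 4-(tert-butyl)phenoxy in place of 4-fluorophenyl on this aromatic carbon gives a 4.6-fold lower number from compound 2 to compound 3 (0.66 log units; beyond the scatter) and putting it in place of phenyl gives a 2.1-fold lower number from compound 1 to compound 3 (0.33 log units; beyond the scatter) in the same assay. The position can therefore carry a larger group that brings in an oxygen, and the number moves downward, the opposite direction to the rise seen when fluorine was added to the phenyl ring, so that compound 3 now needs the least compound of the three. No measured finding is available to explain this drop.

Compound 3 differs from compound 1 and compound 2 by both the oxygen link and the tert-butyl group at once, so the compounds shown cannot say which of the two goes with the lower number; a plain phenoxy group or a 4-(tert-butyl)phenyl group would pull them apart. On these data alone, it also remains open whether the number would keep falling with a different kind of group on this carbon, such as an amine or a carboxylic acid.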